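The source may report more compounds than this note shows. Statements on the series, on what has been measured and on what is new or still open speak of the compounds shown alone.

Compound 2 `C[C@@H]1CN[C@@H](C2CCCCC2)C(=O)N(C)[C@H](C)C(=O)N[C@H](Cc2ccc(F)cc2)C(=O)NCCCc2ccccc2O1` reads <= 10 ug/mL in a physicochemical assay for solubility (on this read-out higher numbers stand for higher solubility and lower numbers for lower solubility), a limit of the assay and not a number. Where compound 2 carries cyclohexyl, compound 1 `CCC[C@@H]1NC[C@@H](C)Oc2ccccc2CCCNC(=O)[C@@H](Cc2ccc(F)cc2)NC(=O)[C@@H](C)N(C)C1=O` has propyl, and in this assay compound 1 gives 100 ug/mL. Going by the values given here, the one measured step that bears on the next change is an at least 10-fold lower number from compound 1 to compound 2 (1.00 log units; beyond the scatter), cyclohexyl in place of propyl on a saturated ring carbon.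

Compound 3 `CC[C@H](C)[C@@H]1NC[C@@H](C)Oc2ccccc2CCCNC(=O)[C@@H](Cc2ccc(F)cc2)NC(=O)[C@@H](C)N(C)C1=O` has sec-butyl in place of cyclohexyl on a saturated ring carbon. Sec-butyl has no ring, and neither has the propyl of compound 1, so much of the drop seen in an at least 10-fold lower number from compound 1 to compound 2 (1.00 log units; beyond the scatter) is expected to be recovered, giving a higher number in this assay. This rests on a single step, and one end of it is a limit. The expected change is an at least 4.0-fold higher number from compound 2 to compound 3 (0.60 log units; beyond the scatter), probably beyond the scatter. For compound 3 the estimate is 40 ug/mL, with an expected range of 10 ug/mL to 120 ug/mL.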

Compound 3, solubility: 100 ug/mL
For compound 3 the middle estimate is 2.5-fold (0.40 log units) below the measured one, within the range that was stated.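

Sec-butyl in place of cyclohexyl on this saturated ring carbon gives an at least 10-fold higher number from compound 2 to compound 3 (1.00 log units; beyond the scatter), so among the three groups shown the low read-out goes with cyclohexyl alone. Methyl in place of hydrogen on the propyl chain gives no change at the digits printed from compound 1 to compound 3 (within the scatter), so in this series a branched open chain with one more carbon reads the same as propyl. The read-out for compound 2 is a limit of the assay and not a number, which leaves the full size of both steps to compound 2 unknown: the limit of <= 10 ug/mL in this assay, at which 1 of the 3 values shown sits.

On these data alone, whether the ring of cyclohexyl or its larger carbon count goes with the drop stays open, and cyclopentyl or a longer chain such as hexyl would separate the two. As far as these compounds go, what an amine or a carboxylic acid on this chain would do in this assay also stays open.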